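Trading benzylamino for diethylamino in compound 4

A few compounds are considered here, and "the series" means these few. Any claim that something is new, unique, unknown or untested is made for them only; others in the source may bear on it.

In a functional assay on A-431 cells (Homo sapiens) for cytotoxicity, read by MTT assay (a higher number here means a weaker inhibitor, a lower number a stronger inhibitor), compound 2 (`N#Cc1c(NCc2ccccc2)c(Cl)c2nc(N)nc(N)c2c1F`) gives 1.4 ug/mL and compound 1 (`N#Cc1c(F)c(Cl)c2nc(N)nc(N)c2c1F`) gives 1.5 ug/mL so these two cannot be told apart. Standing clearly apart from compound 2 is compound 3 (`N#Cc1c(NCc2ccccc2)c(F)c2nc(N)nc(N)c2c1F`) with 12.9 ug/mL as its number.

Compound 4 (`CCN(CC)c1c(C#N)c(F)c2c(N)nc(N)nc2c1Cl`) differs from compound 2 in one group: diethylamino in place of benzylamino on an aromatic carbon. Within the data shown here, two measured steps bear on this change. The more relevant one changed the same carbon, with benzylamino in place of fluoro, and it gave a 1.1-fold lower number from compound 1 to compound 2 (0.03 log units; within the scatter) in this assay so that carbon has so far tolerated a large change of group. The other step, with fluoro in place of chloro on a different carbon, gave a 9.2-fold higher number from compound 2 to compound 3 (0.96 log units; beyond the scatter) and shows that small edits can matter in this small set. Compound 4 keeps the chloro group of compound 2, so that larger step is not repeated here. Among the measured compounds shown here, no measured compound carries diethylamino, which leaves real uncertainty and calls for a wide range.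

The expected outcome is a 1.4-fold higher number from compound 2 to compound 4 (0.15 log units; within the scatter) in this assay and so no change beyond the scatter. Compound 4 is estimated at 2 ug/mL in this assay (expected range 0.7 ug/mL to 6.5 ug/mL)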

Compound 4, half-maximal inhibitory concentration: 7.3 ug/mL
Compound 4: middle estimate off by 3.7-fold (0.56 log units), on the low side; measured number above the stated range.
By their numbers in this assay, from the lowest: compounds 2 and 1 (each within the scatter of the next); then compounds 4 and 3 (each within the scatter of the next).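

In this assay, this carbon proves less forgiving than the earlier swap of fluoro for benzylamino suggested, since diethylamino in place of benzylamino gives a 5.2-fold higher number from compound 2 to compound 4 (0.72 log units; beyond the scatter), and diethylamino in place of fluoro gives a 4.9-fold higher number from compound 1 to compound 4 (0.69 log units; beyond the scatter). Size alone does not order these three groups: diethylamino has fewer heavy atoms than benzylamino, yet it gives the weaker result, while the much smaller fluoro and the larger benzylamino cannot be told apart. No measurement shown here accounts for this loss of potency.

The change also removes two features at once, because benzylamino carries both an aromatic ring and a hydrogen-bond donor that diethylamino lacks, so the compounds shown cannot say which of these matters, if either does. Ethylamino, which keeps the amine hydrogen without the ring, and a tertiary amine that keeps the benzyl group, such as methyl(benzyl)amino, would pull those two features apart at this carbon.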